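Capping the phenol: compound 3 to compound 4

The compounds below may be only part of what the source reports. "The series", "measured", "known", "first", "only" and "open" are said of these compounds alone.

Of the compounds shown here, three sharing one core have been measured in a functional assay on U-87MG ATCC cells (Homo sapiens) for antiproliferative activity, read by MTT assay, with a stated time of 48 h; a higher number here means a weaker inhibitor, a lower number a stronger inhibitor. Compound 1 `COc1ccc(N/C=C\C(=O)c2cn(-c3ccccc3)nc2-c2ccc(F)cc2)cc1` gives 2500 nM; compound 2 `COc1ccc(-c2nn(-c3ccccc3)cc2C(=O)/C=C\Nc2ccc(Cl)cc2)cc1` gives 8860 nM; compound 3 `COc1ccc(-c2nn(-c3ccccc3)cc2C(=O)/C=C\Nc2ccc(O)cc2)cc1` gives 3730 nM. Among these three numbers compound 3 stands second highest: its nearest neighbour is compound 1, whose number lies within the scatter of that of compound 3, and its furthest is compound 2, whose number lies beyond it. For the measured compounds named here, the one single-point step among the measured compounds runs a 2.4-fold lower number from compound 2 to compound 3 (0.38 log units; beyond the scatter), a modest change.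

Compound 4 `COc1ccc(N/C=C\C(=O)c2cn(-c3ccccc3)nc2-c2ccc(OC)cc2)cc1` differs from compound 3 in one place: methyl in place of hydrogen on an oxygen on an aromatic ring. Going by the values given here, no measured step exchanges hydrogen for methyl on an oxygen, so the step from compound 2 to compound 3 bears on it only as a change at the same aromatic carbon of the anilino ring, and that change was itself modest. Compound 1 and compound 3, which differ elsewhere, give numbers within the scatter of each other, which supports nothing large for a small change here either. The step of a 1.2-fold lower number from compound 3 to compound 4 (0.07 log units; within the scatter) is therefore expected to stay within the scatter, with no clear direction. For compound 4 the expected value in this assay is 3200 nM, in a range from 1200 nM to 8500 nM.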

Compound 4, half-maximal inhibitory concentration: > 50000 nM
Compound 4 ended at the assay's limit; the forecaster's own chance of this, stated with the estimate: 5%; at least 15-fold (1.19 log units) between middle value and limit.
By their numbers in this assay, from the lowest: compounds 1 and 3 (each within the scatter of the next); then compound 2. At a limit, above all of these: compound 4.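

In this assay compound 4 gives > 50000 nM, which is a limit of the assay and not a number: the limit of > 50000 nM in this assay, at which 1 of the 4 values shown sits. Capping the hydroxy as methoxy is thus no small change at this place, for the step reads an at least 13-fold higher number from compound 3 to compound 4 (1.12 log units; beyond the scatter), whereas the earlier exchange on the same aromatic carbon, a 2.4-fold lower number from compound 2 to compound 3 (0.38 log units; beyond the scatter), was only modest. The other two steps, an at least 5.6-fold higher number from compound 2 to compound 4 (0.75 log units; beyond the scatter) and an at least 20-fold higher number from compound 1 to compound 4 (1.30 log units; beyond the scatter), sharpen the point: compound 1 already carries the (4-methoxyphenyl)amino group and compounds 2 and 3 carry a methoxy on the other aromatic ring, so among these four compounds a single methoxy goes with measurable values, and only compound 4, with methoxy in both places, reaches the limit.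

What the compounds shown leave open is whether the loss belongs to methoxy itself, or whether an ethoxy, an amine or a carboxylic acid on the same aromatic carbon would behave alike. From the compounds shown here alone, they also give no reason for the loss, and how far the value of compound 4 lies beyond its limit remains unknown.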